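Amino for Trifluoromethyl on a Hydrazone Benzamide

The source may report more compounds than this note shows. Statements on the series, on what has been measured and on what is new or still open speak of the compounds shown alone.

Compound 1 `CC(/C=N/N(C)c1ccc([N+](=O)[O-])cc1)=N\NC(=O)c1ccc(N)cc1` gives > 12000 nM in a functional assay on cells (Splenocyte, Mus musculus, strain BALB/c) for inhibition, read by scintillation counting and thymidine incorporation, with a stated time of 72 h (on this read-out higher numbers stand for weaker inhibition and lower numbers for stronger inhibition), a limit of the assay.
Compound 2 `CC(/C=N/Nc1ccc([N+](=O)[O-])cc1)=N\NC(=O)c1ccccc1N` gives 4900 nM in this assay.
Compound 3 `CC(/C=N/Nc1ccc([N+](=O)[O-])cc1)=N\NC(=O)c1ccc(C(F)(F)F)cc1` gives > 12000 nM in this assay, a limit of the assay.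

Compound 3 thus stands at the limit and not at a number; the limit of > 12000 nM in this assay, at which 2 of the 3 values shown sit, marks where it sits. Compound 4 `CC(/C=N/Nc1ccc([N+](=O)[O-])cc1)=N\NC(=O)c1ccc(N)cc1` differs from compound 3 in one place: amino in place of trifluoromethyl on an aromatic carbon. Among the measured compounds shown here, no step between measured compounds covers this change, so its size is only an expectation. Compound 1, which also carries an amino group, sits at the same limit with > 12000 nM. The step of an at least 1.2-fold lower number from compound 3 to compound 4 (0.07 log units; that floor lies within the scatter) is therefore expected to be small, none beyond the scatter. Compound 4 is expected to give 10000 nM, within 3000 nM to 30000 nM.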

Compound 4, half-maximal inhibitory concentration: > 12000 nM
Compound 4: only a limit was reported; the forecaster's own chance of this, stated with the estimate: 55%; at least 1.2-fold (0.07 log units) between middle value and limit.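

this assay now gives a first readable step for the amino group on the benzamide side: 4-aminophenyl in place of 2-aminophenyl on the carbonyl carbon brings an at least 2.4-fold higher number from compound 2 to compound 4 (0.38 log units; beyond the scatter). The steps to compound 4 from compound 3 and from compound 1 cannot be read, as each joins two limits. Compound 4 adds no number to the series: the limit of > 12000 nM in this assay, at which 3 of the 4 values shown sit.

Still open, on these data alone, is how far beyond this limit compound 1, compound 3 and compound 4 lie. Also open, as far as these compounds go, is whether a hydroxyl or a carboxylic acid in place of the amino group would hold the value of compound 2, which gives 4900 nM.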